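Fluoro in place of bromo: expecting compound 4

The source may report more compounds than this note shows. Statements on the series, on what has been measured and on what is new or still open speak of the compounds shown alone.

In a functional assay on A549 cells (Homo sapiens) for cytotoxicity, read by MTT assay, with a stated time of 72 h (a higher number here means a weaker inhibitor, a lower number a stronger inhibitor), compound 1 `Cc1ccc(S(=O)(=O)c2nc3ccccc3nc2Nc2cccc(N)c2)cc1` gives 1950 nM, compound 2 `COc1ccc(S(=O)(=O)c2nc3ccccc3nc2Nc2cccc(N)c2)cc1` gives 340 nM, and compound 3 `Nc1cccc(Nc2nc3ccccc3nc2S(=O)(=O)c2ccc(Br)cc2)c1` gives 1120 nM. Compound 3 stands close to compound 1, with a 1.7-fold lower number from compound 1 to compound 3 (0.24 log units; within the scatter), and apart from compound 2, with a 3.3-fold higher number from compound 2 to compound 3 (0.52 log units; beyond the scatter). Compound 4 `Nc1cccc(Nc2nc3ccccc3nc2S(=O)(=O)c2ccc(F)cc2)c1` differs from compound 3 at one place: fluoro in place of bromo on an aromatic carbon. At this same place, methoxy in place of methyl gave a 5.7-fold lower number from compound 1 to compound 2 (0.76 log units; beyond the scatter), so only compound 2 departs from the others. Going by the values given here, no fluoro compound has been measured, and fluoro is not methoxy, so no step beyond the scatter is expected. The estimate means a 1.1-fold lower number from compound 3 to compound 4 (0.05 log units; within the scatter), which is expected to stay within the scatter. Compound 4 is expected at 1000 nM, within a range of 400 nM to 2500 nM.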

Compound 4, half-maximal inhibitory concentration: 6840 nM
Estimate against measurement, compound 4: 6.8-fold (0.84 log units) below, and the stated range ends below it.
By their numbers in this assay, from the lowest: compound 2; then compounds 3 and 1 (each within the scatter of the next); then compound 4.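

In this assay, exchanging one single-atom group for another at this position is not neutral: fluoro in place of bromo gives a clear loss (a 6.1-fold higher number from compound 3 to compound 4 (0.79 log units; beyond the scatter)). Methyl and bromo had stood within the scatter of each other, yet fluoro separates from methyl as well (a 3.5-fold higher number from compound 1 to compound 4 (0.55 log units; beyond the scatter)), so a group need not be methoxy to move the number here. The span across this position also grows, with fluoro far from methoxy (a 20-fold higher number from compound 2 to compound 4 (1.30 log units; beyond the scatter)). Going by these compounds, whether chloro or an amine here would sit nearer bromo or fluoro remains open. Nothing available on these compounds accounts for the fluoro result.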